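From Phenyl to Naphthalen-1-yl

The compounds below may be only part of what the source reports. "The series", "measured", "known", "first", "only" and "open" are said of these compounds alone.

In an ADME assay on a cell-free system (plasma, Homo sapiens) for metabolic stability, tested at 1 uM (a lower number here means that the compound disappears faster, a higher number that the compound lasts longer), compound 1 `C=CC(=O)NCC1CCN(S(=O)(=O)c2ccc(NC(=O)OCc3ccccc3)cc2)CC1` gives > 6 h, which is a limit of the assay and not a number. Compound 2 `C=CC(=O)NC1CCN(S(=O)(=O)c2ccc(C(=O)NCc3ccccc3)cc2)CC1` gives > 6 h, also a limit. Compound 2 therefore stands at the limit of > 6 h in this assay, at which 2 of the 2 values shown sit. Compound 3 `C=CC(=O)NC1CCN(S(=O)(=O)c2ccc(C(=O)NCc3cccc4ccccc34)cc2)CC1` keeps the rest of compound 2 and changes one group: naphthalen-1-yl in place of phenyl on a saturated chain carbon bound to an amide-type nitrogen. Within the data shown here, no measured step shows what such a change does. The expected change in this assay is none beyond the scatter, an estimated a number no higher from compound 2 to compound 3 (the limit leaves the size open). For compound 3 the estimated half-life is 6 h, with an expected range from 3.5 h to 10 h.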

Compound 3, half-life: > 6 h
Compound 3 ended at the assay's limit (the forecaster's own chance of this, stated with the estimate: 75%); the middle value lies on the limit itself.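

No step can be read from compound 2 to compound 3: both results in this assay are limits, not numbers. The compounds shown leave open how long each truly lasts, and whether naphthalen-1-yl in place of phenyl changes that: the limit of > 6 h in this assay, at which 3 of the 3 values shown sit.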